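A few compounds are considered here, and "the series" means these few. Any claim that something is new, unique, unknown or untested is made for them only; others in the source may bear on it.

Measured compounds:

Compound 1, `CCCc1nc(-c2ccccc2)c(CNCCN2CCN(c3ccccc3OC)CC2)o1`: 39.7%
Compound 2, `CCCc1nc(-c2ccccc2)c(CNCCCN2CCN(c3cccc(C(F)(F)F)c3)CC2)o1`: 51.6%

Both were tested in an assay on HEK293 cells for inhibition of Voltage-dependent T-type calcium channel subunit alpha-1G (Homo sapiens), read by fluorescence, tested at 10 uM; a higher number here means more inhibition at the concentration tested (going by the name of the read-out), a lower number less inhibition. Compound 1 has the lower of the two numbers: compound 2 gives a higher reading, and the gap between them lies beyond the usual scatter of such measurements. Within the data shown here, since the two compounds differ in more than one place, only the two values themselves can be compared; no single step connects them.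

The unmeasured compound 3, `CCCc1nc(-c2ccccc2)c(CNCCN2CCN(c3ccccc3C(F)(F)F)CC2)o1`, comes from compound 1 by one change:

trifluoromethyl in place of methoxy on an aromatic carbon

Among the measured compounds shown here, no single-change step between measured compounds is available to guide this one. Compound 2 also carries a trifluoromethyl group, though on a different carbon and with a longer chain, and its reading in this assay is the higher of the two measured. On that slim basis, a modest rise from compound 1 is expected, of about a number 6.3 percentage points higher from compound 1 to compound 3 (within the scatter), most of which could still lie within the scatter. Compound 3 is therefore estimated to give 46% in this assay, with a likely range from 28% to 64%.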

Compound 3, a percentage reported as inhibition, at one concentration (the size of the read-out at that concentration, not a potency): 54.6%
Compound 3: the middle estimate sits 8.6 percentage points below what was measured, and the stated range covers the measured number.
By their numbers in this assay, from the lowest: compound 1; then compounds 2 and 3 (each within the scatter of the next).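

In this assay, replacing methoxy with trifluoromethyl on an aromatic carbon, ortho to a large group, gives a number 14.9 percentage points higher from compound 1 to compound 3 (beyond the scatter) and is the only single-change step shown in this series. The two values compared earlier came from compounds that differ in more than one place, whereas here the change from 2-methoxyphenyl to 2-(trifluoromethyl)phenyl is the only difference, so the shift in the reading can be tied to this one swap at this position. The measurements shown do not explain why the swap raises the reading.

A single step also cannot show whether other groups at this carbon, such as a chlorine atom, a nitrile or an amine, would give a similar reading, or whether the same swap would have a similar effect on a compound with a longer chain. As far as these compounds go, because each reading comes from one concentration, it remains open how the potency of the two compounds compares.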